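Notes on compound 4: (2-cyanobenzyl)oxy in the series

The source may hold more compounds than are shown below. What is called first, only, known or untested is meant among the compounds shown, and "the series" means these compounds.

Going by the values given here, compound 3 `CCCCCCCCOC1CC(=O)Nc2c1c(C)nn2-c1ncnc2nc[nH]c12` gives 8 nM in a functional assay on HEK293 cells for agonist activity at G-protein coupled receptor 39 (Homo sapiens), read by scintillation proximity assay and inositol phosphate accumulation, with a stated time of 75 min, in the presence of a further agent that is not named here (on this read-out higher numbers stand for an effect only at larger amounts of compound and lower numbers for an effect already at smaller amounts), the second highest of the three numbers so far. Compound 2 `Cc1nn(-c2ncnc3nc[nH]c23)c2c1C(c1ccc(F)cc1Cl)CC(=O)N2` gives 9 nM, and the step of a 1.1-fold lower number from compound 2 to compound 3 (0.05 log units; within the scatter) lies within the scatter. Compound 1 `Cc1nn(-c2ncnc3nc[nH]c23)c2c1C(OCc1cc(F)cc3c1OCOC3)CC(=O)N2` gives 1.5 nM; the step of a 5.3-fold higher number from compound 1 to compound 3 (0.73 log units; beyond the scatter) is the only one beyond the scatter. Compound 4 `Cc1nn(-c2ncnc3nc[nH]c23)c2c1C(OCc1ccccc1C#N)CC(=O)N2` carries 2-cyanophenyl in place of heptyl on a saturated chain carbon bound to an oxygen on a saturated carbon. The step from compound 1 to compound 3 bears on it most: there a ring-bearing group at the same place was traded for a chain and the number rose, whereas compound 4 restores a ring group there, though 2-cyanophenyl rather than the group of compound 1. A move back toward the number of compound 1 is therefore expected, a 2.7-fold lower number from compound 3 to compound 4 (0.43 log units; beyond the scatter). Compound 4 is expected to give 3 nM, from 1 nM to 10 nM.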

Compound 4, half-maximal effective concentration: 8 nM
Beside the measured number, compound 4's estimate is 2.7-fold (0.43 log units) below it; the measured number falls inside the stated range.
By their numbers in this assay, from the lowest: compound 1; then compounds 3, 4 and 2 (each within the scatter of the next).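

In this assay, no change at the digits printed from compound 3 to compound 4 (within the scatter) shows that octyloxy and (2-cyanobenzyl)oxy cannot be told apart at this place, so an aromatic ring here does not by itself separate a group from a chain. The ring alone does not match the group of compound 1, as a 5.3-fold higher number from compound 1 to compound 4 (0.73 log units; beyond the scatter) remains, while a 1.1-fold lower number from compound 2 to compound 4 (0.05 log units; within the scatter) also lies within the scatter. No available evidence bears on this result.

Still open, on these data alone, is whether the nitrile matters at all, which plain benzyl would test against compound 4. Also open, as far as these compounds go, is whether a carboxylic acid or an amine in its place would move the number.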